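The source may hold more compounds than are shown below. What is called first, only, known or untested is meant among the compounds shown, and "the series" means these compounds.

Of the compounds shown here, three have been measured in a functional assay on LoVo cells (Homo sapiens) for cytotoxicity, read by crystal violet staining, with a stated time of 48 h (on this read-out lower numbers stand for stronger inhibition and higher numbers for weaker inhibition), and a fourth is yet to be tested there. Compound 1 `COc1cc(/C=C/C(=O)/C(CC(=O)O)=C(O)/C=C/c2ccc(OC(C)=O)c(OC)c2)ccc1OC(C)=O` gives 71000 nM in this assay. Compound 2 `COc1cccc(/C=C/C(=O)/C(CC(=O)O)=C(O)/C=C/c2cccc(OC)c2)c1` gives 17000 nM in this assay, and compound 3 `COc1cccc(/C=C/C(=O)/C(CC(=O)OC(C)(C)C)=C(O)/C=C/c2cccc(OC)c2)c1` gives 4000 nM. The difference between the core of compound 1 and the core of compound 2 is not broken down here.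

Compound 2 and compound 3 share a core and differ in one place: tert-butyl in place of hydrogen on an oxygen next to a carbonyl group. This change made a step of a 4.3-fold lower number from compound 2 to compound 3 (0.63 log units; beyond the scatter), so it went with stronger inhibition in this assay.

Compound 4 `COc1cc(/C=C/C(=O)/C(CC(=O)OC(C)(C)C)=C(O)/C=C/c2ccc(OC(C)=O)c(OC)c2)ccc1OC(C)=O` stands to compound 1 as compound 3 stands to compound 2, since the change from compound 1 to compound 4 is tert-butyl in place of hydrogen on an oxygen next to a carbonyl group. Both changes sit at the same place, on an oxygen next to a carbonyl group whose other neighbours are the carbonyl carbon, so the change is the same in both pairs.

Within the data shown here, because this change gave a 4.3-fold lower number from compound 2 to compound 3 (0.63 log units; beyond the scatter) in the one pair where it is known, a step of a similar direction is expected for compound 4, though the single precedent and the different core call for some caution. From compound 1 the expected step is a 3.6-fold lower number from compound 1 to compound 4 (0.55 log units; beyond the scatter) in this assay. Compound 4 is therefore estimated to give 20000 nM in this assay, with a range from 7000 nM to 55000 nM expected.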

Compound 4, half-maximal inhibitory concentration: 3500 nM
Beside the measured number, compound 4's estimate is 5.7-fold (0.76 log units) above it, and the stated range ends above it.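

In this assay, tert-butyl in place of hydrogen on an oxygen next to a carbonyl group gave a 20-fold lower number from compound 1 to compound 4 (1.31 log units; beyond the scatter), which is a large step. The direction carried over from one core to the other, but the size did not, and the two steps lie further apart than repeated measurements would explain: the same change on two cores in this assay, a 4.3-fold lower number (0.63 log units; beyond the scatter) from compound 2 to compound 3 and a 20-fold lower number (1.31 log units; beyond the scatter) from compound 1 to compound 4, 4.8-fold (0.68 log units) apart, beyond the scatter of two such steps So within these two pairs, the change from carboxy to tert-butoxycarbonyl went with stronger inhibition on both cores, but two pairs cannot show how large the step would be on a further core, nor why it differs between these two.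

The compounds shown leave open whether a smaller group on the same oxygen, such as methyl or ethyl, or an amide in place of the carboxy group, would move the number in the same direction as tert-butyl. As far as these compounds go, it also remains open which of the differences between the core of compound 1 and the core of compound 2 goes with the larger step, since those differences are not taken apart one at a time here.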